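The source may report more compounds than this note shows. Statements on the series, on what has been measured and on what is new or still open speak of the compounds shown alone.

Compound 1 `c1ccc(-c2ccccc2OCc2c[nH]cn2)cc1`: 102%
Compound 2 `c1ccc(-c2ccno2)c(OCC2=NCCN2)c1`: 91%

In a functional assay for activation of Alpha-1A adrenergic receptor (Homo sapiens) (a lower number here means a smaller maximal response, a higher number a larger maximal response), compound 2 stands lowest of the two measured compounds, and its nearest neighbour, compound 1, lies higher by a gap beyond the usual scatter. Compound 3 `c1ccc(-c2ccno2)c(OCc2c[nH]cn2)c1` has not yet been measured. It differs from compound 2 in one place: a group of 5 heavy atoms (3 carbon, 2 nitrogen; one five-membered aromatic ring with 2 hetero atoms) in place of a group of 5 heavy atoms (3 carbon, 2 nitrogen; one five-membered non-aromatic ring with 2 hetero atoms), on a saturated chain carbon bound to an oxygen on an aromatic ring. Among the measured compounds shown here, no measured pair shows this exact exchange, so no step can be quoted for it. A small rise is expected because compound 1, carrying the same entering group, gives 102%. The expected step is a number 7 percentage points higher from compound 2 to compound 3 (within the scatter), near the edge of the scatter. Compound 3 is estimated at 98%, between 82% and 110%.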

Compound 3, largest response reached (reported as maximum), in percent of the reference or control that the assay uses: 91%
The estimate for compound 3 lay 7 percentage points above the measured number; low and high end bracket the measured number.
By their numbers in this assay, from the lowest: compounds 2 and 3 (each within the scatter of the next); then compound 1.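

In this assay, 1H-imidazol-4-yl in place of the non-aromatic ring, on a saturated chain carbon bound to an oxygen on an aromatic ring, gives no change at the digits printed from compound 2 to compound 3 (within the scatter), so this exchange alone does not separate the two groups. By contrast, 1,2-oxazol-5-yl in place of phenyl on an aromatic carbon gives a number 11 percentage points lower from compound 1 to compound 3 (beyond the scatter), a modest drop. The data offer no explanation for either result. On these data alone, whether an amine in place of 1,2-oxazol-5-yl, or a longer chain carrying 1H-imidazol-4-yl, would shift the maximal response remains open.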